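A few compounds are considered here, and "the series" means these few. Any claim that something is new, unique, unknown or untested is made for them only; others in the source may bear on it.

Of the compounds shown here, three built on one shared core have been tested in a functional assay on HCT-116 cells (Homo sapiens) for positive allosteric modulation, read by MTT assay, with stated times of 24 h and 48 h, tested at 2.5 uM; on this read-out lower numbers stand for less inhibition of growth and higher numbers for more inhibition of growth at the one concentration tested. Compound 1 `CS(=O)(=O)c1ccc(-c2cnc3[nH]cc(-c4nnc(-c5ccc(F)cc5)o4)c(=O)c3c2)cc1` carries a 4-fluorophenyl group and gives 39.5%, the highest of the three numbers. Compound 2 `CS(=O)(=O)c1ccc(-c2cnc3[nH]cc(-c4nnc(-c5ccccc5)o4)c(=O)c3c2)cc1` has hydrogen in that place and gives 27.2%. Compound 3 `CS(=O)(=O)c1ccc(-c2cnc3[nH]cc(-c4nnc(-c5ccc(Cl)cc5)o4)c(=O)c3c2)cc1` has chloro there and gives 24.9%. Taking the fluoro away in either way lowered the read-out beyond the scatter: a number 12.3 percentage points lower from compound 1 to compound 2 (beyond the scatter) and a number 14.6 percentage points lower from compound 1 to compound 3 (beyond the scatter). Between the two replacements themselves the gap is small, since a number 2.3 percentage points lower from compound 2 to compound 3 (within the scatter) stays within the scatter.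

Compound 4 `Cc1ccc(-c2nnc(-c3c[nH]c4ncc(-c5ccc(S(C)(=O)=O)cc5)cc4c3=O)o2)cc1` is the next member and has not yet been measured. It differs from compound 1 by methyl in place of fluoro on an aromatic carbon, so a 4-fluorophenyl group becomes a 4-methylphenyl group, the new group sitting para to a large group. Both measured steps that swapped the fluoro for something else bear on this change, and each gave a modest fall. Compound 4 is therefore expected to sit a modest way below compound 1, by a step of about a number 12.5 percentage points lower from compound 1 to compound 4 (beyond the scatter) in this assay. The estimated value for compound 4 is 27%, with a likely range from 15% to 40%.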

Compound 4, percent growth inhibition at one concentration: 54.8%
Beside the measured number, compound 4's estimate is 27.8 percentage points below it; measured number above the stated range.
By their numbers in this assay, from the lowest: compounds 3 and 2 (each within the scatter of the next); then compound 1; then compound 4.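

In this assay the methyl group of compound 4 reverses the direction seen so far: both earlier swaps away from fluoro lowered the number, whereas this one gives a number 15.3 percentage points higher from compound 1 to compound 4 (beyond the scatter). The gain is larger still when set against the other two groups at this place, with a number 27.6 percentage points higher from compound 2 to compound 4 (beyond the scatter) and a number 29.9 percentage points higher from compound 3 to compound 4 (beyond the scatter), so the 4-fluorophenyl group is no longer the top of the series and the 4-methylphenyl group now is. Exchanging one heavy atom for another, with no ring, hydrogen-bond donor, hydrogen-bond acceptor or charge added, is enough to move the number this far at this place, and no measurement shown accounts for the rise.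

From the compounds shown here alone, whether a longer chain such as ethyl, or a methoxy group, an amine or a carboxylic acid, would extend the gain or lose it at this place remains open. It is also open whether methyl would give a similar gain elsewhere on this ring, since every compound shown varies only the group para to a large group.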